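Thiophen-2-yl for Phenyl, Repeated on a Second Core

A few compounds are considered here, and "the series" means these few. Any claim that something is new, unique, unknown or untested is made for them only; others in the source may bear on it.

Compound 1 `Oc1cccc(-c2cc(-c3ccccc3)cc(-c3ccccc3)n2)c1`, compound 2 `Oc1cccc(-c2cc(-c3ccccc3)cc(-c3cccs3)n2)c1` and compound 3 `Oc1cccc(-c2cc(-c3ccccc3)nc(-c3ccccc3)c2)c1` were tested in an assay on isolated protein for inhibition of DNA topoisomerase 1 (Homo sapiens), with a stated time of 30 min, tested at 100 uM; on this read-out higher numbers stand for a stronger effect at the one concentration tested and lower numbers for a weaker effect. In this assay compound 1 gives 12.9%, compound 2 gives 51.2% and compound 3 gives 11.5%. The change from compound 1 to compound 2 is thiophen-2-yl in place of phenyl on an aromatic carbon and it made a step of a number 38.3 percentage points higher from compound 1 to compound 2 (beyond the scatter). Compound 3 is built from the same atoms as compound 1, joined differently; the difference between the two cores is not broken down here. Compound 4 `Oc1cccc(-c2cc(-c3ccccc3)nc(-c3cccs3)c2)c1`, not yet measured, carries the same change on the core of compound 3: thiophen-2-yl in place of phenyl on an aromatic carbon. Because this change gave a number 38.3 percentage points higher from compound 1 to compound 2 (beyond the scatter), a step of similar size is expected, estimated as a number 33.5 percentage points higher from compound 3 to compound 4 (beyond the scatter). Compound 4 is therefore expected to give about 45% in this assay, estimated between 20% and 65%.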

Compound 4, a percentage reported as inhibition, at one concentration (the size of the read-out at that concentration, not a potency): 9.1%
For compound 4 the middle estimate is 35.9 percentage points above the measured one; the measured number lies below the stated range.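

On the core of compound 3, thiophen-2-yl in place of phenyl gave a number 2.4 percentage points lower from compound 3 to compound 4 (within the scatter) in this assay, so the large gain seen on the core of compound 1 did not reappear. The two steps differ from each other: the same change on two cores in this assay, a number 38.3 percentage points higher (beyond the scatter) from compound 1 to compound 2 and a number 2.4 percentage points lower (within the scatter) from compound 3 to compound 4, 40.7 percentage points apart, beyond the scatter of two such steps. These two pairs show that the effect of this change in this series depends on the core it is placed on, but they do not show which feature of the cores decides the outcome or how the change would behave on any further core.

The compounds shown leave open how furan-2-yl or an amine in the same place would fare on either core. They also leave open whether a carboxylic acid in place of the hydroxyl of the 3-hydroxyphenyl group would alter the difference between the two cores.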